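Removing the nitro group: from compound 2 to compound 4

The source may report more compounds than this note shows. Statements on the series, on what has been measured and on what is new or still open speak of the compounds shown alone.

Measured compounds:
compound 1 `N#CC1CN1C(=O)Nc1ccc(S(N)(=O)=O)cc1` 188000 nM
compound 2 `N#CC1CN1C(=O)Nc1ccc([N+](=O)[O-])cc1` 3900 nM
compound 3 `CCOC(=O)CNC(=O)N1CC1C#N` 51000 nM

In a functional assay on A-375 cells (Homo sapiens) for inhibition (a higher number here means a weaker inhibitor, a lower number a stronger inhibitor), compound 2 gives the lowest number of the three shown. Compound 4 `N#CC1CN1C(=O)Nc1ccccc1` differs from it by hydrogen in place of nitro on an aromatic carbon. For the measured compounds named here, the one measured step at this position, a 48-fold lower number from compound 1 to compound 2 (1.68 log units; beyond the scatter), shows that the group on that aromatic carbon matters a great deal in this assay; no step to a bare hydrogen is known, so the direction of the present change is uncertain. The author expects the loss of the nitro to raise the number, with a 10-fold higher number from compound 2 to compound 4 (1.01 log units; beyond the scatter), and estimates for compound 4 a value of 40000 nM, within 8000 nM to 200000 nM.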

Compound 4, half-maximal inhibitory concentration: 11000 nM
The estimate for compound 4 lay 3.6-fold (0.56 log units) above the measured number, and the stated range covers the measured number.
By their numbers in this assay, from the lowest: compound 2; then compound 4; then compound 3; then compound 1.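

In this assay the bare hydrogen gives a 2.8-fold higher number from compound 2 to compound 4 (0.45 log units; beyond the scatter) and also a 17-fold lower number from compound 1 to compound 4 (1.23 log units; beyond the scatter) for the replacement of sulfamoyl. The nitro group therefore improves on hydrogen only modestly, whereas sulfamoyl gives a far higher number than hydrogen, so most of the earlier gap between compound 1 and compound 2 lies on the sulfamoyl side. Nothing measured here accounts for either step.

As far as these compounds go, it remains open whether an amine, a carboxylic acid or a methoxy group on that aromatic carbon would give a number lower than that of compound 2.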